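One amide change and an expected shift in cytotoxicity

The source may report more compounds than this note shows. Statements on the series, on what has been measured and on what is new or still open speak of the compounds shown alone.

Measured compounds:
compound 1 `CCN(CC)c1ccc2cc(C(=O)NC3CC3)c(=O)oc2c1`: > 100000 nM in a functional assay on HeLa cells (Homo sapiens) for cytotoxicity, read by MTT assay, with a stated time of 72 h; a higher number here means a weaker inhibitor, a lower number a stronger inhibitor
compound 2 `NNC(=O)c1cc2ccc(OCc3ccccc3)cc2oc1=O`: > 100000 nM

Compound 1 reaches only the edge of what the method can report: in this assay compound 1 gives > 100000 nM, which is a limit and not a number. Compound 2 likewise stops at a limit, as > 100000 nM shows. Going by the values given here, the two values share (the limit of > 100000 nM in this assay, at which 2 of the 2 values shown sit), so compound 1 stands alongside the one other value rather than above or below it, and no step between measured compounds can be drawn.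

Compound 3 `CCN(CC)c1ccc2cc(C(=O)N/N=C(/C)c3cccnc3)c(=O)oc2c1` differs from compound 1 in one place: a group of 9 heavy atoms (7 carbon, 2 nitrogen; one six-membered aromatic ring with 1 hetero atom) in place of a group of 3 heavy atoms (3 carbon; one three-membered non-aromatic ring of carbon only), on an amide-type nitrogen. Among the compounds with values here, with no measured step to lean on, the step of an at least 2.5-fold lower number from compound 1 to compound 3 (0.39 log units; beyond the scatter) is an expectation only, set toward somewhat stronger inhibition, a little beyond the scatter. Compound 3 is accordingly estimated at 40000 nM, between 8000 nM and 150000 nM, with a real chance that it, too, ends at a limit.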

Compound 3, half-maximal inhibitory concentration: 70000 nM
Beside the measured number, compound 3's estimate is 1.8-fold (0.24 log units) below it; measured number inside the range.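

In this assay, going by these compounds alone, compound 3 gives 70000 nM, the only value in this set that is a number and not a limit, so a change on the amide-type nitrogen can bring the reading inside what the method can report. Putting the larger group with its six-membered aromatic ring in place of cyclopropyl gives an at least 1.4-fold lower number from compound 1 to compound 3 (0.15 log units; that floor lies within the scatter). As far as these compounds go, only that floor can be stated, and the true size of the step stays unknown, since the other end of it is a limit: the limit of > 100000 nM in this assay, at which 2 of the 3 values shown sit.

The compounds shown leave open whether the hetero atom of the ring, the double bond outside aromatic rings or the added size alone accounts for the reading. From the compounds shown here alone, how a longer alkyl chain or a carboxylic acid on the same nitrogen would read in this assay also remains open.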